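A few compounds are considered here, and "the series" means these few. Any claim that something is new, unique, unknown or untested is made for them only; others in the source may bear on it.

Measured compounds:
compound 1 `COc1ccc(-c2nc(Cc3c[nH]c4ccccc34)no2)c(OC)c1`: 9300 nM
compound 2 `COc1cc(-c2noc(-c3ccccc3)n2)cc(OC)c1OC`: > 50000 nM
compound 3 `COc1cc(-c2noc(-c3ccc(NC(=O)OC(C)(C)C)cc3)n2)cc(OC)c1OC`: 9200 nM

In an ADME assay on cells (Splenocyte, Mus musculus, strain BALB/c) for cytotoxicity, read by CCK-8 assay, with a stated time of 48 h (a lower number here means that less compound is tolerated, a higher number that more compound is tolerated), compound 3 gives 9200 nM, the lowest of the two full numbers, while compound 1 gives 9300 nM, which lies within the scatter of compound 3. For compound 2 the assay reports only a limit, > 50000 nM, and no number. One measured step joins these: an at least 5.4-fold lower number from compound 2 to compound 3 (0.73 log units; beyond the scatter), a change that brought the number from the limit of > 50000 nM in this assay, at which 1 of the 3 values shown sits, down to a full value.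

Compound 4 `COc1cc(-c2noc(-c3ccc(N)cc3)n2)cc(OC)c1OC` differs from compound 3 by hydrogen in place of tert-butoxycarbonyl on a nitrogen on an aromatic ring. Within the data shown here, no measured pair reproduces this change exactly; the step from compound 2 to compound 3 concerns the whole (tert-butoxycarbonyl)amino group, and removing only the tert-butoxycarbonyl part undoes a portion of it. Compound 4 is therefore expected to sit between compound 3 and the limit of compound 2, as an estimated step of a 2.2-fold higher number from compound 3 to compound 4 (0.34 log units; beyond the scatter). The estimate for compound 4 is 20000 nM, with a range from 7000 nM to 60000 nM.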

Compound 4, half-maximal cytotoxic concentration: > 50000 nM
Compound 4 ended at the assay's limit (the forecaster's own chance of this, stated with the estimate: 25%); middle value at least 2.5-fold (0.39 log units) away from the limit.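

Removing the tert-butoxycarbonyl alone gave an at least 5.4-fold higher number from compound 3 to compound 4 (0.73 log units; beyond the scatter) in this assay, so the amino group left on this aromatic carbon does not retain the lower number of compound 3. Across compound 2, compound 3 and compound 4, the lower number therefore goes with the complete (tert-butoxycarbonyl)amino group and not with the nitrogen alone. Compound 4 now stands at a limit, as compound 2 does, and the step between these two cannot be read: the limit of > 50000 nM in this assay, at which 2 of the 4 values shown sit.

The compounds shown leave open whether an acetyl group or a methoxycarbonyl group on this nitrogen would also lower the number, or whether the tert-butyl part is needed. On these data alone, with only limits for compound 2 and compound 4, any difference between these two also remains unknown.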